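Swapping a pivalate for a toluate on a taxane ester

The compounds below may be only part of what the source reports. "The series", "measured", "known", "first", "only" and "open" are said of these compounds alone.

Compound 2 `C=C1[C@H](OC(C)=O)[C@@H](OC(=O)C(C)(C)C)[C@@H](OC(C)=O)C(C)(C)/C=C/[C@H](C)[C@H](OC(=O)c2ccccc2)[C@@]2(O)C[C@@](C)(OC(C)=O)[C@H](OC(C)=O)[C@@H]2[C@H]1OCC(C)C` — 18900 nM
Compound 1 `C=C1[C@H](OC(=O)c2cccc(C)c2)[C@@H](O)[C@@H](O)C(C)(C)/C=C/[C@H](C)[C@H](OC(=O)c2ccccc2)[C@@]2(O)C[C@@](C)(O)[C@H](OC(C)=O)[C@@H]2[C@H]1OCC(C)C` — 12000 nM

Of the compounds shown here, two have been measured in a toxicity assay on HEK-293T cells (Homo sapiens) for cytotoxicity, read by MTT assay, with a stated time of 48 h; a lower number here means a stronger inhibitor, a higher number a weaker inhibitor. Compound 2 gives 18900 nM, the highest of the two numbers. Its nearest neighbour is compound 1, which gives 12000 nM; the gap between these two lies within the usual scatter, so the data do not separate them. For the measured compounds named here, no pair of measured compounds differs in only one place, so no single step has been quantified.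

Compound 3 `C=C1[C@H](OC(C)=O)[C@@H](OC(=O)c2cccc(C)c2)[C@@H](OC(C)=O)C(C)(C)/C=C/[C@H](C)[C@H](OC(=O)c2ccccc2)[C@@]2(O)C[C@@](C)(OC(C)=O)[C@H](OC(C)=O)[C@@H]2[C@H]1OCC(C)C` is the next member. It differs from compound 2 in one place: 3-methylphenyl in place of tert-butyl on a carbonyl carbon. The rest of the shared core, with its other acetates and the benzoate, is unchanged.

The two measured values sit close together and neither carries a pivalate-to-toluate comparison, so nothing in the data points in a clear direction for this change. The step from compound 2 to compound 3 in this assay is therefore expected to be a 1.3-fold lower number from compound 2 to compound 3 (0.10 log units; within the scatter), essentially no step beyond the scatter. For compound 3 the estimated value in this assay is 15000 nM, within a range from 6000 nM to 40000 nM.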

Compound 3, half-maximal inhibitory concentration: 7600 nM
For compound 3 the middle estimate is 2.0-fold (0.30 log units) above the measured one; low and high end bracket the measured number.
By their numbers in this assay, from the lowest: compounds 3, 1 and 2 (each within the scatter of the next, the first and the last beyond it).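

In this assay, putting 3-methylphenyl in place of tert-butyl on a carbonyl carbon gives a 2.5-fold lower number from compound 2 to compound 3 (0.40 log units; beyond the scatter). This is the only step among the compounds shown that isolates one place, and it shows that the group on this ester carbonyl can move the number modestly beyond the scatter while the rest of the shared core stays unchanged. No measurement bears on why the number moves, so the step stands only as an observed direction and size.

As far as these compounds go, whether a plain phenyl, an aminophenyl or a longer chain on the same carbonyl carbon would move the number further, or reverse the step, remains open. From the compounds shown here alone, it also remains open whether the same change would hold on a core with free hydroxyl groups, as in compound 1, which differs from compound 3 in more than one place and so cannot answer this.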